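Amino for chloro: an ortho case and a meta case

The source may hold more compounds than are shown below. What is called first, only, known or untested is meant among the compounds shown, and "the series" means these compounds.

Compound 1 `ClCc1ccccc1Cn1cnc2c(Cl)nc(Cl)nc21` and compound 2 `ClCc1cccc(Cn2cnc3c(Cl)nc(Cl)nc32)c1` share the same atoms joined differently; the difference between the two cores is not broken down here. In a functional assay on BT-549 cells (Homo sapiens) for cytotoxicity, read by sulforhodamine B assay, with a stated time of 48 h (a lower number here means a stronger inhibitor of growth, a higher number a weaker inhibitor of growth), compound 1 gives 450 nM, and compound 2 gives 1690 nM. Compound 3 `Nc1nc(Cl)c2ncn(Cc3ccccc3CCl)c2n1` carries the change amino in place of chloro on an aromatic carbon relative to compound 1, and in this assay compound 3 gives 8130 nM, so that an 18-fold higher number from compound 1 to compound 3 (1.26 log units; beyond the scatter). Compound 4 `Nc1nc(Cl)c2ncn(Cc3cccc(CCl)c3)c2n1` stands to compound 2 as compound 3 stands to compound 1, through the change (amino in place of chloro on an aromatic carbon). Since the same change is measured once, the step from compound 2 to compound 4 is expected to be about a 15-fold higher number from compound 2 to compound 4 (1.17 log units; beyond the scatter), resting on an 18-fold higher number from compound 1 to compound 3 (1.26 log units; beyond the scatter). Compound 4 is therefore estimated at 25000 nM, with a range of 8000 nM to 80000 nM.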

Compound 4, concentration for 50% growth inhibition: 4070 nM
For compound 4 the middle estimate is 6.1-fold (0.79 log units) above the measured one, outside the stated range (below it).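

On the core of compound 2, amino in place of chloro gives a 2.4-fold higher number from compound 2 to compound 4 (0.38 log units; beyond the scatter) in this assay, so the number rises in both pairs shown. The size of the step, however, does not carry from one core to the other: the same change on two cores in this assay, an 18-fold higher number (1.26 log units; beyond the scatter) from compound 1 to compound 3 and a 2.4-fold higher number (0.38 log units; beyond the scatter) from compound 2 to compound 4, 7.5-fold (0.88 log units) apart, beyond the scatter of two such steps

These two pairs show that the direction held while the size did not, but they do not show why the steps differ or how the change would behave on any further core. The compounds shown leave open what a methoxy group or a dimethylamino group, in place of the same chloro between two ring nitrogen atoms, would do on either core. They also leave open whether such groups would show the same gap between the two cores.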